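Sulfonyl versus benzoyl on the shared core chain

The source may report more compounds than this note shows. Statements on the series, on what has been measured and on what is new or still open speak of the compounds shown alone.

Compound 3 `O=C(NCCNc1nccc(-c2c(-c3cccc(F)c3)nc3sccn23)n1)c1ccccc1` gives 5060 nM in a functional assay on A-375 cells (Homo sapiens) for cytotoxicity, read by MTT assay (a higher number here means a weaker inhibitor, a lower number a stronger inhibitor), the lowest of the three numbers. Compound 1 `O=S(=O)(NCCNc1nccc(-c2c(-c3cccc(F)c3)nc3sccn23)n1)c1ccc(Cl)cc1` gives 18600 nM and compound 2 `O=S(=O)(NCCNc1nccc(-c2c(-c3cccc(F)c3)nc3sccn23)n1)c1cccc(F)c1` gives 14900 nM; between these two sulfonyl-bearing compounds the change is a 1.2-fold lower number from compound 1 to compound 2 (0.10 log units; within the scatter). Putting benzoyl in place of the sulfonyl group gave a 3.7-fold lower number from compound 1 to compound 3 (0.57 log units; beyond the scatter) and a 2.9-fold lower number from compound 2 to compound 3 (0.47 log units; beyond the scatter). Compound 4 `O=S(=O)(NCCCNc1nccc(-c2c(-c3cccc(F)c3)nc3sccn23)n1)c1ccccc1` is not yet measured; it differs from compound 3 by ((phenylsulfonyl)amino)methyl in place of benzamido on a saturated chain carbon, two bonds along the chain from a nitrogen on an aromatic ring. Within the data shown here, this reverses the benzoyl-for-sulfonyl change and also extends the chain, for which the three measured compounds give no precedent. Compound 4 is therefore expected to give a higher number, near the two sulfonyl-bearing compounds, as a 2.6-fold higher number from compound 3 to compound 4 (0.41 log units; beyond the scatter). The estimate for compound 4 is 13000 nM, within 5000 nM to 35000 nM.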

Compound 4, half-maximal inhibitory concentration: 6600 nM
Estimate against measurement, compound 4: 2.0-fold (0.29 log units) above; low and high end bracket the measured number.
By their numbers in this assay, from the lowest: compounds 3 and 4 (each within the scatter of the next); then compounds 2 and 1 (each within the scatter of the next).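

In this assay, ((phenylsulfonyl)amino)methyl in place of benzamido on a saturated chain carbon gives little change (a 1.3-fold higher number from compound 3 to compound 4 (0.12 log units; within the scatter)), so a sulfonyl group here does not by itself bring the higher numbers of compound 1 and compound 2. The same group also sits lower than both (a 2.3-fold lower number from compound 2 to compound 4 (0.35 log units; beyond the scatter); a 2.8-fold lower number from compound 1 to compound 4 (0.45 log units; beyond the scatter)), but each of these steps changes the ring substituent and the chain together. No supporting data bear on why these steps arise.

As far as these compounds go, the separate contributions of chain length and ring substituent remain open. So does the effect of a longer chain, or of an amine or a carboxylic acid on the phenyl ring.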